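This account rests on a few compounds, and the source may have more. Where it says the series, first, only, none or still open, it means among the compounds named here.

Measured so far in a functional assay on MGC-803 cells (Homo sapiens) for inhibition, read by sulforhodamine B assay; on this read-out higher numbers stand for weaker inhibition and lower numbers for stronger inhibition:
- compound 1 `COc1ccc(NC2=CC(=O)c3c(nc4n3[C@H]3OC[C@@H](O)[C@H]3OC4)C2=O)cc1` gives 2150 nM.
- compound 2 `O=C1C(NC2CCCCC2)=CC(=O)c2c1nc1n2[C@H]2OC[C@@H](O)[C@H]2OC1` gives only a limit of the assay, > 8000 nM.
- compound 3 `O=C1C(Nc2ccccc2F)=CC(=O)c2c1nc1n2[C@H]2OC[C@@H](O)[C@H]2OC1` gives 2000 nM.

Compound 3 holds the lower of the two numbers, yet the step between these two is a 1.1-fold lower number from compound 1 to compound 3 (0.03 log units; within the scatter), within the scatter, so the two aryl amines stand level; the third value is a limit. The exchange to cyclohexyl gives an at least 3.7-fold higher number from compound 1 to compound 2 (0.57 log units; beyond the scatter) and, read the other way, an at least 4.0-fold lower number from compound 2 to compound 3 (0.60 log units; beyond the scatter); both steps rest on (the limit of > 8000 nM in this assay, at which 1 of the 3 values shown sits).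

Compound 4 `O=C1C(NCc2ccccc2)=CC(=O)c2c1nc1n2[C@H]2OC[C@@H](O)[C@H]2OC1` is not yet measured. It differs from compound 3 by benzyl in place of 2-fluorophenyl on an amine nitrogen. Within the data shown here, no measured step tests this exact change. The aryl-to-aryl swap between compound 1 and compound 3 was flat, whereas the swap to cyclohexyl cost at least a modest amount. Benzyl keeps an aromatic ring, as 2-fluorophenyl does, but is not itself an aryl group, which places it between the aryl substituents and cyclohexyl; a modest rise in number is therefore expected, smaller than that seen for compound 2. The expected step is a 2.0-fold higher number from compound 3 to compound 4 (0.30 log units; within the scatter). The estimate for compound 4 is 4000 nM, with a range of 1500 nM to 12000 nM.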

Compound 4, half-maximal inhibitory concentration: 3490 nM
Compound 4: middle estimate off by 1.1-fold (0.06 log units), on the high side; low and high end bracket the measured number.
By their numbers in this assay, from the lowest: compounds 3, 1 and 4 (each within the scatter of the next). At a limit, above all of these: compound 2.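

In this assay, moving from a directly attached aryl ring to benzyl on the amine nitrogen gives a 1.7-fold higher number from compound 3 to compound 4 (0.24 log units; within the scatter) and a 1.6-fold higher number from compound 1 to compound 4 (0.21 log units; within the scatter), so the benzyl amine stands level with both aryl amines, and the earlier flat aryl-to-aryl swap now extends to a group that is not an aryl group. The exchange of cyclohexyl for benzyl gives a step beyond the scatter, so among the groups shown, the three bearing an aromatic ring, in compounds 1, 3 and 4, stand together, and only compound 2, with no such ring, goes against them. Compound 2 gives only a limit of the assay, and the step of an at least 2.2-fold lower number from compound 2 to compound 4 (0.36 log units; beyond the scatter) rests on that limit: the limit of > 8000 nM in this assay, at which 1 of the 4 values shown sits.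

As far as these compounds go, the true size of the gap between compound 2 and the three compounds with an aromatic ring stays open, as does whether the aromatic ring itself is what separates them from cyclohexyl. A phenethyl chain, a pyridyl ring or an open-chain n-butyl group on the same nitrogen would bear on that question.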